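The source may hold more compounds than are shown below. What is called first, only, known or untested is meant among the compounds shown, and "the series" means these compounds.

In a functional assay on the whole organism for positive allosteric modulation, with Mus musculus as the target (a lower number here means that less compound is needed, a higher number that more compound is needed for the effect), compound 1 (`CCC(=O)N(c1ccccc1C)C1CCCC1N(C)C`) gives 7 mg/kg and compound 2 (`CCC(=O)N(c1ccc(F)cc1)C1CCCC1N(C)C`) gives 5 mg/kg, values within the usual scatter of each other, whereas compound 3 (`CCC(=O)N(c1ccc(F)c(Cl)c1)C1CCCC1N(C)C`) gives 0.2 mg/kg. Compound 2 therefore stands close to compound 1 and far from compound 3. Compound 4 (`CCC(=O)N(c1ccc(C(C)=O)cc1)C1CCCC1N(C)C`) has acetyl in place of fluoro on an aromatic carbon, para to a large group: acetyl in place of fluoro on an aromatic carbon. Among the compounds with values here, the only measured step bearing on this is a 25-fold lower number from compound 2 to compound 3 (1.40 log units; beyond the scatter), a large change from chloro in place of hydrogen on an aromatic carbon. It keeps the fluoro, so it gives no direction for this exchange. In this assay, only a small move to a higher number is expected, a 1.6-fold higher number from compound 2 to compound 4 (0.20 log units; within the scatter). Compound 4 is expected at 8 mg/kg, with an estimated range of 1.5 mg/kg to 40 mg/kg.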

Compound 4, dose for half-maximal effect: > 50 mg/kg
Compound 4: only a limit was reported; the forecaster's own chance of this, stated with the estimate: 10%; middle value at least 6.2-fold (0.79 log units) away from the limit.
By their numbers in this assay, from the lowest: compound 3; then compounds 2 and 1 (each within the scatter of the next). At a limit, above all of these: compound 4.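

Within the data shown here, compound 4 has only a limit, not a number: the limit of > 50 mg/kg in this assay, at which 1 of the 4 values shown sits. In this assay, acetyl in place of fluoro, para to a large group, gives an at least 10-fold higher number from compound 2 to compound 4 (1.00 log units; beyond the scatter), the first sign that an exchange at this position can raise the number needed. The earlier step, a 25-fold lower number from compound 2 to compound 3 (1.40 log units; beyond the scatter), kept the fluoro and ran the other way, so it could not show this. The compounds shown leave open how far the number of compound 4 lies beyond its limit. They also leave open whether a nitrile, a methoxy group or plain hydrogen at this position would raise the number as well.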